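The compounds below may be only part of what the source reports. "The series", "measured", "known", "first", "only" and "open" are said of these compounds alone.

Compound 1 `COC(=O)c1c(-c2ccc([N+](=O)[O-])cc2)oc2cc(OC)ccc2c1=O` carries a methyl ester on the shared core. In a functional assay on MCF7 cells (Homo sapiens) for cytotoxicity, read by MTT assay, with a stated time of 6 days (on this read-out lower numbers stand for an effect already at smaller amounts and higher numbers for an effect only at larger amounts of compound), compound 1 gives > 25 ug/mL, which is a limit of the assay and not a number. Compound 2 `COC(=O)c1c(-c2ccc(O)cc2)oc2cc(OC)ccc2c1=O` has hydroxy in place of nitro on an aromatic carbon. In this assay compound 2 gives > 25 ug/mL, again a limit rather than a number. Both measured values sit at the limit of > 25 ug/mL in this assay, at which 2 of the 2 values shown sit. The step that the two limits leave unreadable from compound 1 to compound 2 is therefore of unknown size. Compound 3 `COc1ccc2c(=O)c(C(=O)O)c(-c3ccc([N+](=O)[O-])cc3)oc2c1` differs from compound 1 by hydrogen in place of methyl on an oxygen next to a carbonyl group. Among the measured compounds shown here, no measured step touches this part of the molecule, and the single measured step cannot be sized, so no direction of change in this assay can be read from the data. Compound 3 is expected, like compound 1, to reach the limit, and is estimated at 40 ug/mL. For compound 3 the expected range runs from 15 ug/mL to 100 ug/mL. The step that the limit leaves unreadable from compound 1 to compound 3 implied by this estimate is expected to stay within the scatter.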

Compound 3, concentration for half-maximal effect: > 25 ug/mL
Compound 3 was reported as a limit (the forecaster's own chance of this, stated with the estimate: 85%); the middle value lies beyond the limit too.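

Compound 1 and compound 3 both give a limit and not a number in this assay, so no step between them can be read: the limit of > 25 ug/mL in this assay, at which 3 of the 3 values shown sit.

The compounds shown leave open whether hydrogen in place of methyl changes the effect at all, and which change on the shared core would give a readable value.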